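The source may hold more compounds than are shown below. What is called first, only, known or untested is meant among the compounds shown, and "the series" means these compounds.

Compound 1 `Cc1ccc(C2C(C#N)=C(N)N(c3ccc(S(N)(=O)=O)cc3)C3=C2CCCC3)cc1` gives 80% in a functional assay on Ehrlich cells (Mus musculus) for cytotoxicity, read by trypan blue exclusion, with a stated time of 2 h, tested at 50 ug/mL; a lower number here means a weaker effect, a higher number a stronger effect of the compound at the concentration tested.
Compound 2 `N#CC1=C(N)N(c2ccc(S(N)(=O)=O)cc2)C2=C(CCCC2)C1c1ccc(O)cc1` gives 60% in this assay.
Compound 3 `N#CC1=C(N)N(c2ccc(S(N)(=O)=O)cc2)C2=C(CCCC2)C1c1ccc(Cl)cc1Cl` gives 50% in this assay.

Among these three numbers compound 3 holds the lowest; its gap to compound 2 is within the scatter, while its gap to compound 1 is beyond it. Compound 4 `N#CC1=C(N)N(c2ccc(S(N)(=O)=O)cc2)C2=C(CCCC2)C1c1c(O)ccc2ccccc12` differs from compound 3 in one place: 2-hydroxynaphthalen-1-yl in place of 2,4-dichlorophenyl on a saturated ring carbon.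

Going by the values given here, two steps bear on this change. Exchanging one aryl group for another on the saturated ring carbon gave a number 30 percentage points lower from compound 1 to compound 3 (beyond the scatter) and a number 10 percentage points lower from compound 2 to compound 3 (within the scatter), the latter within the scatter. The entering group carries a hydroxy, and the step of a number 20 percentage points lower from compound 1 to compound 2 (beyond the scatter) shows that a hydroxy in place of methyl lowered the number modestly. Nothing here points to a large movement in either direction, so a step within the scatter, at most a slight rise toward the number of compound 2, is expected for compound 4, namely a number 5 percentage points higher from compound 3 to compound 4 (within the scatter).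

Compound 4 is therefore estimated at 55% in this assay, with a range from 35% to 75%.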

Compound 4, a percentage reported as activity, at one concentration (the size of the read-out at that concentration, not a potency): 20%
Compound 4: middle estimate off by 35 percentage points, on the high side; measured number outside the range, below it.
By their numbers in this assay, from the lowest: compound 4; then compounds 3 and 2 (each within the scatter of the next); then compound 1.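

In this assay, going by these compounds alone, the group on the saturated ring carbon can move the number further than the earlier compounds showed: exchanging 2,4-dichlorophenyl for 2-hydroxynaphthalen-1-yl gave a number 30 percentage points lower from compound 3 to compound 4 (beyond the scatter), and compared with 4-methylphenyl the same group gave a number 60 percentage points lower from compound 1 to compound 4 (beyond the scatter), the widest step at this position. A hydroxy alone does not set the level, since 4-hydroxyphenyl also carries one, yet the change to 2-hydroxynaphthalen-1-yl gave a number 40 percentage points lower from compound 2 to compound 4 (beyond the scatter). Compound 4 thus stands clearly below the other three compounds, the first sign that this position tolerates a drop of that size.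

No measurement shown explains this fall. As far as these compounds go, whether the second aromatic ring or the place of the hydroxy matters more stays open, as does how an amine or a carboxylic acid on this aryl group would read.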